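A Second Methyl Group on the Phenyl Ring

The compounds below may be only part of what the source reports. "The series", "measured", "known", "first", "only" and "open" are said of these compounds alone.

Three measured compounds share one large core and differ only in small groups at its two ends. Compound 1, `COc1cc2c(Oc3ccc(NC(=O)c4cn(-c5ccccc5)nn4)cc3F)ccnc2cc1OCCCN1CCCCC1`, carries an unsubstituted phenyl ring and a piperidin-1-yl group on its side chain. In a functional assay on A549 cells (Homo sapiens) for cytotoxicity, read by MTT assay, with a stated time of 72 h (on this read-out lower numbers stand for stronger inhibition and higher numbers for weaker inhibition), compound 1 gives 130 nM. Compound 2, `COc1cc2c(Oc3ccc(NC(=O)c4cn(-c5ccccc5C)nn4)cc3F)ccnc2cc1OCCCN1CCCCC1`, differs by one change: methyl in place of hydrogen on an aromatic carbon. Compound 2 gives 3230 nM, so this one methyl made a 25-fold higher number from compound 1 to compound 2 (1.40 log units; beyond the scatter). Compound 3, `COc1cc2c(Oc3ccc(NC(=O)c4cn(-c5ccccc5C)nn4)cc3F)ccnc2cc1OCCCN1CCN(C)CC1`, keeps that methyl and alters the side chain, giving a 1.0-fold lower number from compound 2 to compound 3 (0.02 log units; within the scatter); compound 3 gives 3100 nM. How compound 3 differs from compound 1 as a whole is not broken down here.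

Compound 4, `COc1cc2c(Oc3ccc(NC(=O)c4cn(-c5c(C)cccc5C)nn4)cc3F)ccnc2cc1OCCCN1CCN(C)CC1`, has not yet been measured. It differs from compound 3 by methyl in place of hydrogen on an aromatic carbon. Going by the values given here, this is the same kind of change as the one from compound 1 to compound 2, but not the same: in compound 2 the entering methyl was only ortho to a large group, while in compound 4 it is ortho to a large group and also meta to a methyl group, since the ring already carries one.

For compound 4 the expected step is a 2.6-fold higher number from compound 3 to compound 4 (0.41 log units; beyond the scatter), smaller than the first methyl's step, because a 25-fold higher number from compound 1 to compound 2 (1.40 log units; beyond the scatter) already moved the number far, and a second methyl on the same ring is expected to add a more modest further rise. Compound 4 is therefore estimated at 8000 nM, with the likely range expected to run from 3000 nM to 25000 nM.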

Compound 4, half-maximal inhibitory concentration: 2180 nM
Compound 4: middle estimate off by 3.7-fold (0.56 log units), on the high side, outside the stated range (below it).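

In this assay, the second methyl group, which turns 2-methylphenyl into 2,6-dimethylphenyl, gives a 1.4-fold lower number from compound 3 to compound 4 (0.15 log units; within the scatter), so these two values cannot be told apart. The same written change, methyl in place of hydrogen on an aromatic carbon, therefore does not carry over as a fixed step within this series, and the two steps differ by more than repeated measurements would explain: the same change on two cores in this assay, a 25-fold higher number (1.40 log units; beyond the scatter) from compound 1 to compound 2 and a 1.4-fold lower number (0.15 log units; within the scatter) from compound 3 to compound 4, 35-fold (1.55 log units) apart, beyond the scatter of two such steps. This does not show why they differ: the ring receiving the methyl already carries one in compound 3 but not in compound 1, and the side chain also differs, with 4-methylpiperazin-1-yl in compound 3 and piperidin-1-yl in compound 1.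

From the compounds shown here alone, it remains open how a plain phenyl ring would read with the 4-methylpiperazin-1-yl side chain, a comparison that could help separate the role of the side chain from that of the methyl already on the ring. Also open, going by these compounds, is whether a chlorine atom or a methoxy group in place of the methyl, or a morpholine on the side chain, would give a step like the large one to compound 2 or the small one to compound 4.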